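The source may hold more compounds than are shown below. What is called first, only, known or untested is meant among the compounds shown, and "the series" means these compounds.

Compound 1 `CCCC[C@@H](O)C(=O)N1C[C@H]2C[C@H]2[C@H]1C(=O)NCc1cc(Cl)ccc1-n1cnnn1` gives 33 10^-6 cm/s in an ADME assay on Caco-2 cells (Homo sapiens) for permeability, read by LC-MS, in the apical to basolateral direction, with a stated time of 60 min, at pH 6.5; a lower number here means that the compound crosses the layer more slowly, a higher number that the compound crosses the layer faster.
Compound 2 `CC(C)(C)[C@@H](O)C(=O)N1C[C@H]2C[C@H]2[C@H]1C(=O)NCc1cc(Cl)ccc1-n1cnnn1` gives 3.8 10^-6 cm/s in this assay.
Compound 3 `CC(C)(C)[C@@H](O)C(=O)N1[C@@H]2C[C@@H]2C[C@H]1C(=O)NCc1cc(Cl)ccc1-n1cnnn1` gives 34 10^-6 cm/s in this assay.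

Compound 1 and compound 2 share one core; compound 3 has another, and the difference between the two cores is not broken down here. Between compound 2 and compound 1 the change is butyl in place of tert-butyl on a saturated chain carbon bound to a carbonyl carbon and an oxygen on a saturated carbon, and it brings an 8.7-fold higher number from compound 2 to compound 1 (0.94 log units; beyond the scatter). Compound 3 and compound 1 lie within the scatter of each other, while compound 3 and compound 2 are separated by a gap beyond the scatter.

Compound 4 `CCCC[C@@H](O)C(=O)N1[C@@H]2C[C@@H]2C[C@H]1C(=O)NCc1cc(Cl)ccc1-n1cnnn1` is not yet measured in this assay. It differs from compound 3 by butyl in place of tert-butyl on a saturated chain carbon bound to a carbonyl carbon and an oxygen on a saturated carbon, the same change as from compound 2 to compound 1. Because compound 3 already gives 34 10^-6 cm/s, an account on the same scale as compound 1, a smaller step than the earlier one is expected here, roughly a 1.3-fold higher number from compound 3 to compound 4 (0.12 log units; within the scatter). Compound 4 is therefore estimated at 45 10^-6 cm/s, with a likely range from 20 10^-6 cm/s to 90 10^-6 cm/s.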

Compound 4, apparent permeability: 35 10^-6 cm/s
The estimate for compound 4 lay 1.3-fold (0.11 log units) above the measured number, within the range that was stated.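

On the second core, butyl in place of tert-butyl gives a 1.0-fold higher number from compound 3 to compound 4 (0.01 log units; within the scatter) in this assay. The change therefore does not carry over in size from one core to the other: the same change on two cores in this assay, an 8.7-fold higher number (0.94 log units; beyond the scatter) from compound 2 to compound 1 and a 1.0-fold higher number (0.01 log units; within the scatter) from compound 3 to compound 4, 8.4-fold (0.93 log units) apart, beyond the scatter of two such steps. Among these compounds, this does not show what lies behind the difference between the two steps or how the change would read on a third core, and each core offers only one pair of compounds in this one assay.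

The compounds shown leave open how a longer chain, an amine or a carboxylic acid would read in the same place on either core. They also leave open whether the two cores would part in the same way with such groups, or whether the gap belongs to the exchange of tert-butyl for butyl alone.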